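This account rests on a few compounds, and the source may have more. Where it says the series, first, only, none or still open, it means among the compounds named here.

Compound 1 `CCCCc1cn(C(c2ccccc2)c2cc3cc(Br)ccc3nc2OC)nn1`: -3.47%
Compound 2 `COc1nc2ccc(Br)cc2cc1C(c1ccccc1)n1cc(-c2ccc(Br)cc2)nn1`: 6.28%

In an ADME assay on HEK293 cells (Homo sapiens) for cytotoxicity, read by sulforhodamine B assay, with a stated time of 48 h, tested at 10 uM (a lower number here means less inhibition, a higher number more inhibition at the concentration tested (going by the name of the read-out)), compound 1 gives -3.47%, the lower of the two numbers shown, with compound 2 as its only neighbour; that neighbour stands a number 9.8 percentage points higher from compound 1 to compound 2 (within the scatter), so the two compounds cannot be told apart on this read-out. Compound 3 `CCCCCCCCc1cn(C(c2ccccc2)c2cc3cc(Br)ccc3nc2OC)nn1` keeps the shared core of compound 1 and changes only the chain: butyl in place of hydrogen on a saturated chain carbon, four bonds along the chain from an aromatic carbon. For the measured compounds named here, no measured step touches this position in the same way. Going by the values given here, the one step that is known, a number 9.8 percentage points higher from compound 1 to compound 2 (within the scatter), replaces the butyl with a 4-bromophenyl and does not move the number beyond the scatter, so on the evidence available the number in this assay stays level across that change at the chain end. Compound 3 is therefore expected to sit close to compound 1, with a step of a number 5.5 percentage points higher from compound 1 to compound 3 (within the scatter) that should not exceed the scatter. The estimate for compound 3 is 2%, ranging from -12% to 16%.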

Compound 3, a percentage reported as inhibition, at one concentration (the size of the read-out at that concentration, not a potency): 14.6%
Compound 3: middle estimate off by 12.6 percentage points, on the low side, within the range that was stated.
By their numbers in this assay, from the lowest: compounds 1, 2 and 3 (each within the scatter of the next, the first and the last beyond it).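

Extending the chain at this position is the first change shown to go beyond the scatter in this assay: butyl in place of hydrogen on a saturated chain carbon, four bonds along the chain from an aromatic carbon, gives a number 18.1 percentage points higher from compound 1 to compound 3 (beyond the scatter), a modest step that shows the chain end is not wholly silent, which the earlier step could not show. Octyl in place of 4-bromophenyl on an aromatic carbon gives a number 8.3 percentage points higher from compound 2 to compound 3 (within the scatter), so those two groups cannot be told apart on this read-out. No measured evidence bears on what lies behind the step.

On these data alone, whether a hexyl chain or a longer chain such as dodecyl would follow the octyl chain remains open. So does the outcome of an amine or a carboxylic acid at the chain end.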